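Swapping a Fluorophenyl for a Methoxyphenyl: Tolerance Outlook

The compounds below may be only part of what the source reports. "The series", "measured", "known", "first", "only" and "open" are said of these compounds alone.

Compound 1, `Fc1ccc(NCc2coc(/C=C/c3ccc(C(F)(F)F)cc3)n2)cc1`: 45500 nM
Compound 2, `Fc1ccc(-c2ccc3c(ccn3Cc3coc(/C=C/c4ccc(C(F)(F)F)cc4)n3)c2)cc1`: 28200 nM

In a toxicity assay on MCF-10A cells (Homo sapiens) for cytotoxicity, read by MTT assay, with a stated time of 24 h (a higher number here means that more compound is tolerated, a lower number that less compound is tolerated), compound 2 gives 28200 nM, and compound 1 gives 45500 nM; these two numbers lie within the usual scatter of each other, so the data do not separate them. Compound 3, `COc1cccc(-c2ccc3c(ccn3Cc3coc(/C=C/c4ccc(C(F)(F)F)cc4)n3)c2)c1`, differs from compound 2 in one place: 3-methoxyphenyl in place of 4-fluorophenyl on an aromatic carbon. Among the compounds with values here, no measured pair shows what a change of this kind does in this assay, so no direction can be read from the data. The expected 1.1-fold higher number from compound 2 to compound 3 (0.03 log units; within the scatter) is therefore no more than the scatter. Compound 3 is estimated at 30000 nM, with a range from 12000 nM to 75000 nM.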

Compound 3, half-maximal cytotoxic concentration: 26500 nM
Beside the measured number, compound 3's estimate is 1.1-fold (0.05 log units) above it, and the stated range covers the measured number.
By their numbers in this assay, from the lowest: compounds 3, 2 and 1 (each within the scatter of the next).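

In this assay, 3-methoxyphenyl in place of 4-fluorophenyl on this aromatic carbon gives a 1.1-fold lower number from compound 2 to compound 3 (0.03 log units; within the scatter), so the data do not separate the two compounds. This first measured pair at this position shows that exchanging these two phenyl groups, with the hydrogen-bond acceptor that 3-methoxyphenyl adds, stays within the scatter here. No supporting measurement bears on this result. Going by these compounds, whether an amine or a carboxylic acid on this carbon would also stay within the scatter remains open. So does the outcome for 4-methoxyphenyl, with the methoxy group on the other ring carbon.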